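Hydrogen in place of methyl on compound 2

The source may report more compounds than this note shows. Statements on the series, on what has been measured and on what is new or still open speak of the compounds shown alone.

Liver microsomes give an early view of how quickly a compound may be cleared, and two compounds with a shared core have been read in an ADME assay on liver for metabolic stability, with Liver microsome (Homo sapiens) as the target, using microsomes; on this read-out higher numbers stand for fast clearance and lower numbers for slow clearance. For compound 1 (`COc1ccc2c(c1)C(=O)N(Cc1ccccc1-c1ccccc1)C2C(=O)NC(C)(C)C`) the reading > 100 mL.min-1.g-1 is a limit of the assay and not a number. For the measured compounds named here, compound 2 (`Cc1c(NS(C)(=O)=O)ccc2c1C(=O)N(Cc1ccccc1-c1ccccc1)C2C(=O)NC(C)(C)C`) gives 88 mL.min-1.g-1 and so holds the only true number so far. Compound 3 (`CC(C)(C)NC(=O)C1c2ccc(NS(C)(=O)=O)cc2C(=O)N1Cc1ccccc1-c1ccccc1`) awaits measurement and carries one small edit of compound 2: hydrogen in place of methyl on an aromatic carbon on an aromatic carbon ortho to a methanesulfonamido group. Going by the values given here, no pair of measured compounds shows this change alone, so the expectation is a slight drop in this assay at most. The estimated step of a 1.3-fold lower number from compound 2 to compound 3 (0.10 log units; within the scatter) stays within the usual scatter of repeat measurements. Compound 3 is estimated at 70 mL.min-1.g-1 with 35 mL.min-1.g-1 to 120 mL.min-1.g-1 as the expected range.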

Compound 3, intrinsic clearance in microsomes in the Liver microsome assay: 59 mL.min-1.g-1
For compound 3 the middle estimate is 1.2-fold (0.07 log units) above the measured one; the range from low to high includes it.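

In the Liver microsome assay, hydrogen in place of methyl at this position, on an aromatic carbon ortho to a methanesulfonamido group, gives a 1.5-fold lower number from compound 2 to compound 3 (0.17 log units; within the scatter), and in a physicochemical assay for lipophilicity, read by HPLC (a lower number here means a more polar compound, a higher number a more lipophilic compound), where compound 2 gives 4.3 and compound 3 gives 4, the same edit gives a number 0.30 log units lower from compound 2 to compound 3 (within the scatter), so neither read-out separates compound 2 from compound 3. In the Liver microsome assay, methanesulfonamido in place of methoxy gives an at least 1.6-fold lower number from compound 1 to compound 3 (0.22 log units; that floor lies within the scatter), so this second comparison offers a floor and not a full size. That floor arises because the reading for compound 1 is a limit of the assay and not a number: the limit of > 100 mL.min-1.g-1 in the Liver microsome assay, at which 1 of the 3 values shown sits.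

From the compounds shown here alone, it remains open whether a larger change at the methyl position, such as an amine or a longer chain, would move the Liver microsome assay beyond the scatter. Going by these compounds, it is also open how a carboxylic acid would read in place of the methanesulfonamido group.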